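The compounds below may be only part of what the source reports. "The series", "measured", "known", "first", "only" and "open" are said of these compounds alone.

Values in a functional assay on MCF7 cells (Homo sapiens) for cytotoxicity, read by MTT assay, with a stated time of 24 h; a lower number here means a stronger inhibitor, a higher number a weaker inhibitor:
Compound 1 `C=CCn1c(=O)c(C=O)cc2ccccc21`: > 100000 nM
Compound 2 `C=CCn1c(=O)c(/C=C/C(=O)/C=C(O)/C=C/c2ccc(O)c(OC)c2)cc2ccccc21`: 23500 nM
Compound 3 `C#CCn1c(=O)c(/C=C/C(=O)/C=C(O)/C=C/c2ccc(O)c(OC)c2)cc2ccccc21`: 15000 nM

The entry for compound 1, > 100000 nM, is a limit of the assay and not a number. For the measured compounds named here, compound 3, at 15000 nM, stands level with compound 2 within the scatter, and these are the only two numbers available. Compound 4 `C#CCn1c(=O)c(/C=C/C(=O)/C=C(O)/C=C/c2ccc(O)c(OC)c2)cc2cc(OC)ccc21` differs from compound 3 by methoxy in place of hydrogen on an aromatic carbon. Going by the values given here, the one measured step, a 1.6-fold lower number from compound 2 to compound 3 (0.19 log units; within the scatter), swaps vinyl for ethynyl elsewhere, so it bears only indirectly on this change. No step beyond the scatter is therefore expected in this assay, and no direction can be favoured. The estimated change is a 1.1-fold lower number from compound 3 to compound 4 (0.03 log units; within the scatter). Compound 4 is expected at 14000 nM, within an estimated range of 5000 nM to 40000 nM.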

Compound 4, half-maximal inhibitory concentration: > 100000 nM
Compound 4: only a limit was reported (the forecaster's own chance of this, stated with the estimate: 4%); at least 7.1-fold (0.85 log units) between middle value and limit.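

In this assay, methoxy in place of hydrogen on an aromatic carbon, meta to a fused ring and para to a fused ring, gives an at least 6.6-fold higher number from compound 3 to compound 4 (0.82 log units; beyond the scatter). It is thus the one step shown that lies beyond the scatter, whereas the change on the chain, a 1.6-fold lower number from compound 2 to compound 3 (0.19 log units; within the scatter), lies within it. The full size of the step stays unknown, for compound 4 sits at a limit and not at a number: the limit of > 100000 nM in this assay, at which 2 of the 4 values shown sit.

As far as these compounds go, whether a hydroxyl, a fluorine or an amine on this carbon would act as methoxy does remains open. So does whether methoxy has the same effect alongside the chain of compound 2.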